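The compounds below may be only part of what the source reports. "The series", "measured", "known", "first", "only" and "open" are said of these compounds alone.

Compound 3 `COC(=O)c1cccc(CSc2nc(N)c(C#N)c(-c3ccc(OCC4CC4)cc3)c2C#N)c1` stands highest of the three numbers in a functional assay on CHO cells for agonist activity at adenosine receptor A2b (Homo sapiens), read by AlphaScreen and cAMP accumulation (a higher number here means that more compound is needed for the effect, a lower number that less compound is needed), with 347 nM. Compound 1 `N#Cc1c(N)nc(SCC(N)=O)c(C#N)c1-c1ccc(OCC2CC2)cc1` gives 31 nM in this assay, and compound 2 `N#Cc1c(N)nc(SCc2cccc(C(N)=O)c2)c(C#N)c1-c1ccc(OCC2CC2)cc1` gives 12.7 nM. Both steps into compound 3 were large, an 11-fold higher number from compound 1 to compound 3 (1.05 log units; beyond the scatter) and a 27-fold higher number from compound 2 to compound 3 (1.44 log units; beyond the scatter), whereas a 2.4-fold lower number from compound 1 to compound 2 (0.39 log units; beyond the scatter) was only modest. Compound 4 `N#Cc1c(N)nc(SCc2ncc[nH]2)c(C#N)c1-c1ccc(OCC2CC2)cc1` differs from compound 3 by 1H-imidazol-2-yl in place of 3-(methoxycarbonyl)phenyl on a saturated chain carbon bound to a sulfur. The entering group carries a hydrogen-bond donor, as do the side groups of compounds 1 and 2, so the two large steps bear on this change and point back toward their values. Compound 4 is therefore expected to show an 8.7-fold lower number from compound 3 to compound 4 (0.94 log units; beyond the scatter) in this assay, a clearly lower number. The estimate for compound 4 is 40 nM, with a range from 10 nM to 160 nM.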

Compound 4, half-maximal effective concentration: 9.5 nM
Compound 4: middle estimate off by 4.2-fold (0.62 log units), on the high side; the measured number lies below the stated range.
By their numbers in this assay, from the lowest: compounds 4 and 2 (each within the scatter of the next); then compound 1; then compound 3.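

In this assay, 1H-imidazol-2-yl on a saturated chain carbon bound to a sulfur removes the penalty seen with 3-(methoxycarbonyl)phenyl, a 37-fold lower number from compound 3 to compound 4 (1.56 log units; beyond the scatter). This five-atom ring matches the larger 3-carbamoylphenyl group, a 1.3-fold lower number from compound 2 to compound 4 (0.13 log units; within the scatter), and gives a lower number than carbamoyl, a 3.3-fold lower number from compound 1 to compound 4 (0.51 log units; beyond the scatter), so a six-membered ring is not required here for a low number. No supporting evidence is available to explain these differences. The compounds shown leave open whether the imidazole hydrogen on nitrogen matters, a question that 1-methylimidazol-2-yl could address. They also leave open how a 3-carboxyphenyl group would compare.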